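A Phenyl for a Methyl on the Aryl Ketone

The compounds below may be only part of what the source reports. "The series", "measured", "known", "first", "only" and "open" are said of these compounds alone.

Compound 1, `COc1cc(-c2nnc3n2NC(c2cccs2)C(C(=O)c2ccc(C)cc2)S3)cc(OC)c1OC`: 12700 nM in a functional assay on A549 cells (Homo sapiens) for cytotoxicity, read by MTT assay, with a stated time of 48 h; a lower number here means a stronger inhibitor, a higher number a weaker inhibitor
Compound 2, `COc1cc(-c2nnc3n2NC(c2ccco2)C(C(=O)c2cccc(Br)c2)S3)cc(OC)c1OC`: 36900 nM
Compound 3, `COc1cc(-c2nnc3n2NC(c2ccco2)C(C(=O)c2ccc(C)cc2)S3)cc(OC)c1OC`: > 100000 nM

Of the three measured compounds, compound 3 is the one for which this assay returns only a limit, (the limit of > 100000 nM in this assay, at which 1 of the 3 values shown sits), and not a number. Compound 4, `COc1cc(-c2nnc3n2NC(c2ccco2)C(C(=O)c2ccc(-c4ccccc4)cc2)S3)cc(OC)c1OC`, differs from compound 3 by phenyl in place of methyl on an aromatic carbon. Among the compounds with values here, no measured step alters this group. The nearest step is an at least 2.7-fold higher number from compound 2 to compound 3 (0.43 log units; beyond the scatter), which shows that the group on the ring at the carbonyl carbon does move the number, while an at least 7.8-fold higher number from compound 1 to compound 3 (0.89 log units; beyond the scatter) concerns the saturated ring carbon and so does not bear on the change at hand. Both steps end in the limit at compound 3, so their sizes are themselves only lower bounds. Given that, the step of an at least 1.2-fold lower number from compound 3 to compound 4 (0.09 log units; that floor lies within the scatter) is expected to be a modest drop at most, and compound 4 is estimated at 80000 nM, within 20000 nM to 300000 nM, with a real chance that compound 4 is again reported only as a limit.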

Compound 4, half-maximal inhibitory concentration: > 100000 nM
Compound 4 gave a limit, no number; the forecaster's own chance of this, stated with the estimate: 55%; middle value at least 1.2-fold (0.09 log units) from the limit.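

In this assay compound 4 gives > 100000 nM as its result, a limit and not a number. Moving from methyl to phenyl at this aromatic carbon thus brings no readable value back while furan-2-yl stays on the saturated ring carbon, though the step between compound 3 and compound 4 cannot be read, as both ends are limits. Within the data shown here, the one readable step is an at least 2.7-fold higher number from compound 2 to compound 4 (0.43 log units; beyond the scatter) and places 4-phenylphenyl, like 4-methylphenyl, on the weaker side of 3-bromophenyl on the carbonyl carbon, and the limit is now shared: the limit of > 100000 nM in this assay, at which 2 of the 4 values shown sit.

Still open, from the compounds shown here alone, is whether phenyl at this place would give a number with thiophen-2-yl on the saturated ring carbon. Also open, going by these compounds, is how an amine or a carboxylic acid in place of that methyl would read.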